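Removing the ring nitrogen: from compound 2 to compound 3

A few compounds are considered here, and "the series" means these few. Any claim that something is new, unique, unknown or untested is made for them only; others in the source may bear on it.

Measured so far in an in vitro functional assay on 1321-N1 cells for antagonist activity at transient receptor potential cation channel subfamily V member 1 (Homo sapiens), read by FLIPR and calcium flux; a higher number here means a weaker inhibitor, a lower number a stronger inhibitor:
compound 1 `CC(C)(C)c1ccc(NC(=O)C2=CCN(c3ncccc3C#N)CC2)cc1` gives 78 nM
compound 2 `CC(C)(C)c1ccc(NC(=O)C2=CCN(c3ncccc3F)CC2)cc1` gives 19 nM

Among the measured compounds shown here, compound 2 has the lowest number of the two; the only measured step is a 4.1-fold lower number from compound 1 to compound 2 (0.61 log units; beyond the scatter). Compound 3 `CC(C)(C)c1ccc(NC(=O)C2=CCN(c3ccccc3F)CC2)cc1` differs from compound 2 by 2-fluorophenyl in place of 3-fluoropyridin-2-yl on an amine nitrogen in a ring. For the measured compounds named here, no measured step bears on this change: the one step known concerns a group on an aromatic carbon, not the ring itself. For compound 3 no step beyond the scatter is therefore expected in this assay, a 1.3-fold higher number from compound 2 to compound 3 (0.12 log units; within the scatter). Compound 3 is estimated at 25 nM, within 7 nM to 90 nM.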

Compound 3, half-maximal inhibitory concentration: 265 nM
Compound 3: the middle estimate sits 11-fold (1.03 log units) below what was measured; measured number above the stated range.
By their numbers in this assay, from the lowest: compound 2; then compound 1; then compound 3.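

In this assay, the ring nitrogen of the group on the amine nitrogen turns out to matter: 2-fluorophenyl in place of 3-fluoropyridin-2-yl gives a 14-fold higher number from compound 2 to compound 3 (1.14 log units; beyond the scatter), a large step where the earlier one, on an aromatic carbon, was modest. The phenyl compound also falls behind the nitrile-bearing pyridine, with a 3.4-fold higher number from compound 1 to compound 3 (0.53 log units; beyond the scatter). Nothing in hand explains this loss. Still open, as far as these compounds go, is whether a pyridine carrying chloro or methyl in place of fluoro keeps the lower number, and whether a phenyl ring carrying a nitrile loses as much.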